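A Third Methoxy on the Aryl Ring at the Carbonyl

The compounds below may be only part of what the source reports. "The series", "measured", "known", "first", "only" and "open" are said of these compounds alone.

In a functional assay on SF-539 cells (Homo sapiens) for cytotoxicity, read by sulforhodamine B assay, with a stated time of 48 h, tested at 1 uM (on this read-out lower numbers stand for a stronger effect and higher numbers for a weaker effect at the one concentration tested), compound 2 `COc1ccc(C(=O)/C=C/c2cc(-c3cc(OC)c(OC)c(OC)c3)n[nH]2)cc1OC` gives 67%, the lowest of the three numbers shown. Compound 1 `COc1cc(-c2cc(/C=C/C(=O)c3ccc(N)cc3)[nH]n2)cc(OC)c1OC` gives 69% in this assay, and the step of a number 2 percentage points lower from compound 1 to compound 2 (within the scatter) lies within the scatter, so the two stand level. Compound 3 `COc1cc(-c2cc(/C=C/C(=O)c3ccc(F)c(F)c3)[nH]n2)cc(OC)c1OC` gives 90% in this assay; the step of a number 23 percentage points higher from compound 2 to compound 3 (beyond the scatter) is a modest weakening, as is a number 21 percentage points higher from compound 1 to compound 3 (beyond the scatter).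

Compound 4 `COc1cc(C(=O)/C=C/c2cc(-c3cc(OC)c(OC)c(OC)c3)n[nH]2)cc(OC)c1OC` differs from compound 2 by methoxy in place of hydrogen on an aromatic carbon, on an aromatic carbon of a six-membered aromatic ring of carbon only, ortho to a methoxy group and meta to a methoxy group. Going by the values given here, no measured step adds or removes a single methoxy; the steps seen swap the whole aryl on the carbonyl carbon, and they show that exchanging 4-aminophenyl for 3,4-dimethoxyphenyl changed little while 3,4-difluorophenyl weakened the effect modestly. One further methoxy on a ring already carrying two is expected to move the number little, so a number 1 percentage points lower from compound 2 to compound 4 (within the scatter) in this assay is expected to stay within the scatter. Compound 4 is estimated at 66% in this assay, within 50% to 82%.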

Compound 4, a percentage reported as activity, at one concentration (the size of the read-out at that concentration, not a potency): 66%
For compound 4 middle estimate and measured number coincide at the digits printed, and the stated range covers the measured number.
By their numbers in this assay, from the lowest: compounds 4, 2 and 1 (each within the scatter of the next); then compound 3.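

In this assay, the step gives a number 1 percentage points lower from compound 2 to compound 4 (within the scatter) for methoxy in place of hydrogen on an aromatic carbon, ortho to a methoxy group and meta to a methoxy group. The earlier steps shown here exchanged the whole aryl on the carbonyl carbon, whereas this one changes a single group and shows that a third methoxy on this ring leaves the two compounds level. No measurement given here bears on why the number holds level.

On these data alone, whether an ethoxy group, a hydroxyl or a chlorine atom at this same place would also leave the number level remains open. So does whether any group on this ring can bring the number lower than the methoxy compounds, beyond the scatter, at the one concentration tested.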